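Compound 2 to compound 3: a phenyl exchange

This account rests on a few compounds, and the source may have more. Where it says the series, first, only, none or still open, it means among the compounds named here.

Compound 1 `Nc1nc(NCCNc2ncc(-c3ncc[nH]3)c(-c3ccc(Cl)cc3Br)n2)ccc1[N+](=O)[O-]` gives > 0.5 h in an ADME assay on microsomes from liver (Rattus norvegicus) for metabolic stability (on this read-out higher numbers stand for a longer-lived compound and lower numbers for a shorter-lived compound), as a limit
Compound 2 `Cc1ccc(-c2nc(NCCNc3ccc([N+](=O)[O-])c(N)n3)ncc2-c2ncc[nH]2)c(Br)c1` gives > 0.5 h in this assay as a limit

Compound 2 stands at > 0.5 h, which is a limit and not a number. Compound 3 `Cc1cc(Cl)ccc1-c1nc(NCCNc2ccc([N+](=O)[O-])c(N)n2)ncc1-c1ncc[nH]1` differs from it by 4-chloro-2-methylphenyl in place of 2-bromo-4-methylphenyl on an aromatic carbon, which places 4-chloro-2-methylphenyl in place of 2-bromo-4-methylphenyl on an aromatic carbon. Among the measured compounds shown here, the one measured step that bears on this change is a step that the two limits leave unreadable from compound 1 to compound 2, an exchange of methyl in place of chloro on an aromatic carbon. Its size cannot be read, and the data amount to the limit of > 0.5 h in this assay, at which 2 of the 2 values shown sit, so they give no direction for the new exchange. In this assay the expected step that the limit leaves unreadable from compound 2 to compound 3 is therefore none beyond the usual scatter. Compound 3 is estimated at 0.7 h, with an expected range from 0.35 h to 1.4 h, and a report as a limit is the likeliest outcome.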

Compound 3, half-life: > 0.5 h
Compound 3: a limit, no number; the forecaster's own chance of this, stated with the estimate: 75%; the middle value lies beyond the limit too.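

In this assay compound 3 gives > 0.5 h, which is a limit. No step among compound 1, compound 2 and compound 3 can therefore be read: the limit of > 0.5 h in this assay, at which 3 of the 3 values shown sit.

The compounds shown leave open what half-life each of the three has and whether any of these phenyl exchanges alters it.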